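A few compounds are considered here, and "the series" means these few. Any claim that something is new, unique, unknown or untested is made for them only; others in the source may bear on it.

Two measured compounds share one core in an assay on isolated protein for inhibition of Rho-associated protein kinase 2 (Homo sapiens), read by a luciferase reporter; a higher number here means a weaker inhibitor, a lower number a stronger inhibitor. Compound 1, `NCC(=O)Nc1cc2cc[nH]c(=O)c2cc1Cl`, gives 120 nM in this assay. Compound 2, `CC(C)c1cccc(C2CNCC2C(=O)Nc2cc3cc[nH]c(=O)c3cc2Cl)c1`, gives 6 nM, the lower of the two numbers, and its gap to compound 1 lies beyond the scatter. Compound 3, `O=C(Nc1cc2cc[nH]c(=O)c2cc1Cl)C1CNCC1c1ccccc1`, differs from compound 2 by hydrogen in place of isopropyl on an aromatic carbon. For the measured compounds named here, no step between measured compounds shows this change, so its size is uncertain; a moderate rise toward weaker inhibition is expected, a 3.3-fold higher number from compound 2 to compound 3 (0.52 log units; beyond the scatter). Compound 3 is therefore expected to give about 20 nM, in a range from 6 nM to 70 nM.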

Compound 3, half-maximal inhibitory concentration: 6 nM
Compound 3: middle estimate off by 3.3-fold (0.52 log units), on the high side, within the range that was stated.
By their numbers in this assay, from the lowest: compounds 2 and 3 (each within the scatter of the next); then compound 1.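

In this assay, hydrogen in place of isopropyl on an aromatic carbon gives no change at the digits printed from compound 2 to compound 3 (within the scatter). The isopropyl group, meta to a large group, is therefore not required for the number seen with compound 2, and 3-isopropylphenyl and phenyl cannot be told apart in this measurement. Nothing available explains why this change leaves the number in place. From the compounds shown here alone, whether a smaller group such as methyl or a group carrying other atoms such as methoxy, a carboxylic acid or an amine would be accommodated on this carbon remains open. So does the effect of a longer chain there.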